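A few compounds are considered here, and "the series" means these few. Any claim that something is new, unique, unknown or untested is made for them only; others in the source may bear on it.

Working notes on the series, all in a functional assay on the whole organism (stomach) for inhibition, with Rattus norvegicus as the target; on this read-out lower numbers stand for an effect already at smaller amounts and higher numbers for an effect only at larger amounts of compound. Compound 1 (`O=C(O)CCC/C=C1\CC2C[C@@H](O)[C@H](/C=C/[C@@H](O)C3COc4ccccc4O3)C2C1`) gives 0.0045 mg/kg. Compound 2 (`O=C(O)CCC/C=C1\CC2C[C@@H](O)[C@H](/C=C/[C@@H](O)CC3COc4ccccc4O3)C2C1`) is reported only as a limit, > 0.3 mg/kg. Compound 3 (`Cc1ccc2c(c1)OCC([C@H](O)/C=C/[C@@H]1C3C/C(=C/CCCC(=O)O)CC3C[C@H]1O)O2`) gives 0.11 mg/kg, the higher of the two actual numbers in this assay.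

Next in line is compound 4 (`COc1ccc2c(c1)OCC([C@H](O)/C=C/[C@@H]1C3C/C(=C/CCCC(=O)O)CC3C[C@H]1O)O2`), with methoxy in place of methyl on an aromatic carbon. Going by the values given here, the one measured step at this aromatic carbon is a 24-fold higher number from compound 1 to compound 3 (1.39 log units; beyond the scatter), which is large and beyond the scatter. That step replaces hydrogen with methyl, so it shows that a substituent here can cost a great deal. It does not compare two substituents with each other. With methyl already present, a further loss of that size is not expected, and a gain back towards compound 1 has no support in the data. The expected change in this assay is a 1.4-fold higher number from compound 3 to compound 4 (0.13 log units; within the scatter), which stays within the scatter. For compound 4 the estimated value is 0.15 mg/kg, with an expected range of 0.04 mg/kg to 0.6 mg/kg.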

Compound 4, dose for half-maximal effect: 0.0021 mg/kg
For compound 4 the middle estimate is 71-fold (1.85 log units) above the measured one; the measured number lies below the stated range.
By their numbers in this assay, from the lowest: compound 4; then compound 1; then compound 3. At a limit, above all of these: compound 2.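

In this assay, the aromatic carbon does not penalise every substituent: a 52-fold lower number from compound 3 to compound 4 (1.72 log units; beyond the scatter), so the loss seen with methyl, a 24-fold higher number from compound 1 to compound 3 (1.39 log units; beyond the scatter), does not carry over to methoxy. Methoxy in place of hydrogen also goes the opposite way to methyl, a 2.1-fold lower number from compound 1 to compound 4 (0.33 log units; beyond the scatter), a modest step, so at this place the outcome depends on which group enters, not simply on a group being present. Nothing in the data shown accounts for the large difference between methyl and methoxy.

The compounds shown leave open whether the gain is particular to methoxy or extends to ethoxy, a hydroxyl group or a fluorine on the same aromatic carbon. They also leave open how methoxy behaves on any other carbon of this aromatic ring.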